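Pyrazoline Series: Aryl Versus Styryl at the Saturated Carbon

This account rests on a few compounds, and the source may have more. Where it says the series, first, only, none or still open, it means among the compounds named here.

Compound 3 `Cc1cc(O)c(C2=NN(c3ccc(S(N)(=O)=O)cc3)C(/C=C/c3ccccc3)C2)cc1Cl` gives 38600 nM in a functional assay on DU-145 cells (Homo sapiens) for antiproliferative activity, with a stated time of 48 h (on this read-out lower numbers stand for stronger inhibition of growth and higher numbers for weaker inhibition of growth), the highest number among the three measured compounds; the nearest is compound 1 `Cc1cc(O)c(C2=NN(c3ccc(S(N)(=O)=O)cc3)C(c3ccccc3O)C2)cc1Cl` with 4950 nM, the furthest compound 2 `Cc1cc(O)c(C2=NN(c3ccc(S(N)(=O)=O)cc3)C(c3ccccc3Cl)C2)cc1Cl` with 3850 nM.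

Compound 4 `COc1ccc(C2CC(c3cc(Cl)c(C)cc3O)=NN2c2ccc(S(N)(=O)=O)cc2)cc1OC` has not yet been measured. It differs from compound 3 by 3,4-dimethoxyphenyl in place of 2-phenylethenyl on a saturated ring carbon.

Among the measured compounds shown here, two measured steps bear on this change, both replacing an aryl group by 2-phenylethenyl on the same saturated ring carbon: a 7.8-fold higher number from compound 1 to compound 3 (0.89 log units; beyond the scatter) and a 10-fold higher number from compound 2 to compound 3 (1.00 log units; beyond the scatter). Read in reverse, returning an aromatic ring to that carbon is associated with a clear drop in the number. The new ring carries its substitution in a pattern not yet seen in the series, so the size of the step is less certain than the direction. Compound 4 is therefore expected to show a 7.7-fold lower number from compound 3 to compound 4 (0.89 log units; beyond the scatter), landing in the region of compound 1 and compound 2. The estimate for compound 4 is 5000 nM, with a range from 1500 nM to 15000 nM.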

Compound 4, concentration for total growth inhibition: 21700 nM
Estimate against measurement, compound 4: 4.3-fold (0.64 log units) below; the measured number lies above the stated range.
By their numbers in this assay, from the lowest: compounds 2 and 1 (each within the scatter of the next); then compounds 4 and 3 (each within the scatter of the next).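

An aromatic ring on this saturated ring carbon does not by itself bring the number down in this assay: with 3,4-dimethoxyphenyl the step is a 1.8-fold lower number from compound 3 to compound 4 (0.25 log units; within the scatter) and so gives no separation from the 2-phenylethenyl compound. The earlier compounds shown here left the identity of the aryl group untested beyond 2-chlorophenyl and 2-hydroxyphenyl, and replacing these gives a 5.6-fold higher number from compound 2 to compound 4 (0.75 log units; beyond the scatter) and a 4.4-fold higher number from compound 1 to compound 4 (0.64 log units; beyond the scatter), so the group carried by the ring matters at this position, not only the presence of the ring. No measured data at hand explain this difference.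

The compounds shown leave open whether a single methoxy group would give a number nearer to those of compound 1 and compound 2 or to that of compound 4. Going by these compounds, how an aminophenyl or carboxyphenyl group would behave on this carbon also remains open.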